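A few compounds are considered here, and "the series" means these few. Any claim that something is new, unique, unknown or untested is made for them only; others in the source may bear on it.

Compound 1 `COc1ccccc1S(=O)(=O)/C=C/c1ccccn1` and compound 2 `COc1ccccc1S(=O)(=O)/C=C/c1ncccc1F` share one core and differ by a single change, (fluoro in place of hydrogen on an aromatic carbon). In an ADME assay on BV-2 cells (Mus musculus) for cytotoxicity, with a stated time of 24 h, tested at 10 uM (on this read-out higher numbers stand for a weaker effect at the one concentration tested and lower numbers for a stronger effect), compound 1 gives 100%, and compound 2 gives 100%, so that no change at the digits printed from compound 1 to compound 2 (within the scatter). Compound 3 `COc1cccc(S(=O)(=O)/C=C/c2ccccn2)c1` holds the same atoms as compound 1 joined differently; the difference between the two cores is not broken down here. In this assay compound 3 gives 100%, level with compounds 1 and 2 within the scatter. Compound 4 `COc1cccc(S(=O)(=O)/C=C/c2ncccc2F)c1` is related to compound 3 by the same change, (fluoro in place of hydrogen on an aromatic carbon), the two places being described in the same words. Because no change at the digits printed from compound 1 to compound 2 (within the scatter) left the read-out where it stood, compound 4 is expected to show a like step, no change at the digits printed from compound 3 to compound 4 (within the scatter). The value expected for compound 4 in this assay is 100%, estimated to lie between 88% and 106%.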

Compound 4, a percentage reported as activity, at one concentration (the size of the read-out at that concentration, not a potency): 100%
The estimate for compound 4 equals the measured number at the digits printed; low and high end bracket the measured number.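

In this assay, putting fluoro in place of hydrogen on an aromatic carbon of the core of compound 3 gives no change at the digits printed from compound 3 to compound 4 (within the scatter). The change thus behaves alike on both cores: the same change on two cores in this assay, no change at the digits printed (within the scatter) from compound 1 to compound 2 and no change at the digits printed (within the scatter) from compound 3 to compound 4, 0 percentage points apart, within the scatter of two such steps. Among these compounds, this shows only that the change leaves the read-out unmoved on these two cores at the one concentration tested; it does not show that a step of visible size would carry over from one core to another, and it gives no potency.

The compounds shown leave open what a different group on the same aromatic carbon, such as an amine, a nitrile or a carboxylic acid, would do to the read-out. They also leave open whether any such group would behave alike on both cores.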